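This account rests on a few compounds, and the source may have more. Where it says the series, first, only, none or still open, it means among the compounds named here.

Two esters of the shared core carry full values in an assay on microsomes from intestine for inhibition of acyl-CoA:cholesterol acyltransferase (Oryctolagus cuniculus); on this read-out lower numbers stand for stronger inhibition and higher numbers for weaker inhibition: compound 1 `CC(C)c1cccc(C(C)C)c1OC(=O)CC(=O)Nc1c(N(C)C)cccc1N(C)C` gives 71 nM, and compound 2 `CC(C)c1cccc(C(C)C)c1NC(=O)CC(=O)Oc1c(C(C)C)cccc1C(C)C` gives 42 nM. Among the compounds with values here, compound 3 `CC(C)c1cccc(C(C)C)c1NC(=O)CC(=O)O` stands apart: in this assay compound 3 returns only a limit, > 5000 nM, the one value of the three that sits at the limit of > 5000 nM in this assay, at which 1 of the 3 values shown sits. So the free acid is the point where measurable inhibition is lost, while both esters keep it. Compound 4 `CCCCC(C)(C)OC(=O)CC(=O)Nc1c(C(C)C)cccc1C(C)C` differs from compound 3 by 1,1-dimethylpentyl in place of hydrogen on an oxygen next to a carbonyl group. Since the measured esters both hold full values, compound 4 is expected to recover a measurable number, a step from the limit estimated as an at least 33-fold lower number from compound 3 to compound 4 (1.52 log units; beyond the scatter). Compound 4 is estimated at 150 nM, between 40 nM and 1000 nM.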

Compound 4, half-maximal inhibitory concentration: 15 nM
Compound 4: the middle estimate sits 10-fold (1.00 log units) above what was measured; measured number below the stated range.
By their numbers in this assay, from the lowest: compound 4; then compounds 2 and 1 (each within the scatter of the next). At a limit, above all of these: compound 3.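

In this assay, 1,1-dimethylpentyl in place of hydrogen on an oxygen next to a carbonyl group brings an at least 330-fold lower number from compound 3 to compound 4 (2.52 log units; beyond the scatter). A chain with no ring and no hydrogen-bond donors or acceptors is therefore enough at this oxygen to give a full value. The step is only a minimum, since its starting point is a limit: the limit of > 5000 nM in this assay, at which 1 of the 4 values shown sits.

The compounds shown leave open whether a shorter chain such as methyl or ethyl would hold this value at the same oxygen. They also leave open how an unbranched pentyl chain or a chain ending in an amine would compare.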